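The source may hold more compounds than are shown below. What is called first, only, known or untested is meant among the compounds shown, and "the series" means these compounds.

Measured so far:
Compound 1 `Cc1ccc(C(=O)Nc2nc(Cl)c3cn(C)nc3n2)cc1`: in a functional assay on CHO cells for antagonist activity at adenosine receptor A2b (Homo sapiens), read by 33P incorporation, with a stated time of 20 min, in the presence of a further agent that is not named here (a lower number here means a stronger inhibitor, a higher number a weaker inhibitor), compound 1 gives > 20000 nM, which is a limit of the assay.
Compound 2 `Cn1cc2c(Cl)nc(N)nc2n1`: in this assay compound 2 gives > 20000 nM, again only a limit.
Compound 3 `Cn1cc2c(Cl)nc(NC(=O)c3ccccc3)nc2n1`: in this assay compound 3 gives > 20000 nM, again only a limit.

Compound 1 therefore stands at the limit only, and every value in the set sits at that same limit (the limit of > 20000 nM in this assay, at which 3 of the 3 values shown sit). Among the compounds with values here, the one step between measured compounds, a step that the two limits leave unreadable from compound 1 to compound 3, cannot be read because both ends are limits. Compound 4 `Cc1ccc(C(=O)Nc2nc(Cl)c3cn(C(C)C)nc3n2)cc1` differs from compound 1 by isopropyl in place of methyl on an aromatic nitrogen. Within the data shown here, no measured step bears on this change, so no shift beyond the scatter can be predicted in either direction in this assay. Compound 4 is expected to stay at the limit, estimated at 30000 nM with a range of 10000 nM to 100000 nM. The expected step is a step that the limit leaves unreadable from compound 1 to compound 4.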

Compound 4, inhibition constant: > 20000 nM
Compound 4: a limit, no number (the forecaster's own chance of this, stated with the estimate: 85%); the middle value lies beyond the limit too.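

No new step can be read between compound 1 and compound 4, as both stand only at a limit in this assay. The compounds shown leave open whether any change to the shared core gives a readable value: the limit of > 20000 nM in this assay, at which 4 of the 4 values shown sit.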